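The compounds below may be only part of what the source reports. "The series", "measured", "known", "first", "only" and "open" are said of these compounds alone.

Four compounds share one core, each carrying a different group on an aromatic carbon of that core, and three of them have been tested in a functional assay for activation of Alpha-1A adrenergic receptor (Homo sapiens), read by calcium flux; a higher number here means that more compound is needed for the effect, a lower number that less compound is needed. Compound 1 `CCN(CC)C(=O)c1ccccc1OCC1=NCCN1` gives in this assay only a limit of the assay, < 5020 nM, and not a number. Compound 3 `Cc1ccnc(-c2ccccc2OCC2=NCCN2)c1` likewise gives in this assay only a limit, < 100000 nM. Within the data shown here, compound 2 `c1cncc(-c2ccccc2OCC2=NCCN2)c1` gives in this assay 2 nM, which is the only full number among the three results. Compound 4 `c1ccc(-c2ccncn2)c(OCC2=NCCN2)c1` has not yet been measured. It differs from compound 2 by pyrimidin-4-yl in place of pyridin-3-yl on an aromatic carbon. Among the measured compounds shown here, no two measured compounds in this set differ in only one place, so no measured step shows how large such an exchange tends to be. A step from compound 2 to compound 4 of a 5.0-fold higher number from compound 2 to compound 4 (0.70 log units; beyond the scatter) is expected, a modest loss that may still fall within the scatter. In this assay compound 4 is therefore expected to give 10 nM, with a range from 1 nM to 100 nM.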

Compound 4, half-maximal effective concentration: < 100000 nM
Compound 4 gave a limit, no number; the forecaster's own chance of this, stated with the estimate: 10%; the middle value is on the limit's open side.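

In this assay, among these compounds, compound 4 gives only a limit of the assay and not a number, so no step from compound 2 to compound 4 can be read. The compounds shown leave open how large the change is when pyrimidin-4-yl takes the place of pyridin-3-yl.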